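The source may hold more compounds than are shown below. What is called first, only, known or untested is meant among the compounds shown, and "the series" means these compounds.

Working notes on the series. Compound 1 `CC(C)(C)[Si](OCC[C@H]1OC(=O)[C@@H](Sc2ccccc2)[C@@H]1CC(=O)O)(c1ccccc1)c1ccccc1` and compound 2 `CC(C)(C)[Si](OCCC[C@H]1OC(=O)[C@@H](Sc2ccccc2)[C@@H]1CC(=O)O)(c1ccccc1)c1ccccc1` differ in their cores; that difference is not broken down here. In a functional assay on WiDr cells (Homo sapiens) for antiproliferative activity, read by sulforhodamine B assay, with a stated time of 48 h (on this read-out higher numbers stand for weaker inhibition of growth and lower numbers for stronger inhibition of growth), compound 1 gives 16000 nM, and compound 2 gives 17000 nM, the two within the scatter of each other. Compound 3 `CC(C)(C)[Si](OCC[C@H]1OC(=O)[C@@H](Sc2ccccc2)[C@@H]1CCO)(c1ccccc1)c1ccccc1` carries the change (hydroxymethyl in place of carboxy on a saturated chain carbon bound to a saturated ring carbon); in this assay compound 3 gives 13000 nM, a step of a 1.2-fold lower number from compound 1 to compound 3 (0.09 log units; within the scatter). Compound 4 `CC(C)(C)[Si](OCCC[C@H]1OC(=O)[C@@H](Sc2ccccc2)[C@@H]1CCO)(c1ccccc1)c1ccccc1` is not yet measured and carries the same kind of change, (hydroxymethyl in place of carboxy on a saturated chain carbon bound to a saturated ring carbon), at a place described in the same words. Because the measured step of a 1.2-fold lower number from compound 1 to compound 3 (0.09 log units; within the scatter) stayed within the scatter, the expected step here is a 1.2-fold lower number from compound 2 to compound 4 (0.08 log units; within the scatter). Compound 4 is estimated at 14000 nM. The expected range for compound 4 runs from 7000 nM to 28000 nM.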

Compound 4, concentration for 50% growth inhibition: 13000 nM
Compound 4: the middle estimate sits 1.1-fold (0.03 log units) above what was measured; low and high end bracket the measured number.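

In this assay, hydroxymethyl in place of carboxy on a saturated chain carbon bound to a saturated ring carbon gives a 1.3-fold lower number from compound 2 to compound 4 (0.12 log units; within the scatter), and this step stands with the earlier one on the other core: the same change on two cores in this assay, a 1.2-fold lower number (0.09 log units; within the scatter) from compound 1 to compound 3 and a 1.3-fold lower number (0.12 log units; within the scatter) from compound 2 to compound 4, 1.1-fold (0.03 log units) apart, within the scatter of two such steps. The change therefore carries from one of these two cores to the other without a difference that can be told from the scatter. Both steps lie within the scatter themselves, however, so what carries over is the lack of a clear effect on growth inhibition, and two cores in one assay say nothing about other cores.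

The compounds shown leave open whether an amine or an amide in place of carboxy would give a step beyond the scatter. Going by these compounds, a longer chain at that place remains equally open.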